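Thiosemicarbazone series: ortho substituent swap on the aryl ring

A few compounds are considered here, and "the series" means these few. Any claim that something is new, unique, unknown or untested is made for them only; others in the source may bear on it.

Measured so far:
Compound 1 `CC1=CC[C@H](C(C)(C)NC(=S)N/N=C/c2ccccc2O)CC1`: 3700 nM
Compound 2 `CC1=CC[C@H](C(C)(C)NC(=S)N/N=C/c2ccccc2Cl)CC1`: 75000 nM

In a functional assay on NCI/ADR-RES cells (Homo sapiens) for inhibition, read by sulforhodamine B assay, with a stated time of 48 h (a lower number here means a stronger inhibitor of growth, a higher number a weaker inhibitor of growth), compound 1 gives 3700 nM and compound 2 gives 75000 nM. Among the measured compounds shown here, compound 2 holds the highest number of the two measured, and the only step measured in this assay, a 20-fold higher number from compound 1 to compound 2 (1.31 log units; beyond the scatter), separates it from compound 1.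

Compound 3 `CC1=CC[C@H](C(C)(C)NC(=S)N/N=C/c2ccccc2[N+](=O)[O-])CC1` has not been measured. It differs from compound 2 by nitro in place of chloro on an aromatic carbon. For the measured compounds named here, no measured step covers a change from chloro to nitro, and the single step known, a 20-fold higher number from compound 1 to compound 2 (1.31 log units; beyond the scatter), tells only that removing hydroxy cost a great deal; it says nothing about what replaces chloro. With nothing pointing in either direction, the expectation is a step of a 1.3-fold lower number from compound 2 to compound 3 (0.10 log units; within the scatter), close to no change beyond the scatter. Compound 3 is therefore estimated at 60000 nM, with a wide range from 12000 nM to 250000 nM in this assay.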

Compound 3, concentration for 50% growth inhibition: 19200 nM
Compound 3: middle estimate off by 3.1-fold (0.49 log units), on the high side, within the range that was stated.
By their numbers in this assay, from the lowest: compound 1; then compound 3; then compound 2.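

Working notes: in this assay the position does not treat all replacements for hydroxy alike, since nitro in place of chloro gives a 3.9-fold lower number from compound 2 to compound 3 (0.59 log units; beyond the scatter) and so recovers part of what compound 2 lost. Recovery is only partial, with a 5.2-fold higher number from compound 1 to compound 3 (0.72 log units; beyond the scatter) still separating nitro from hydroxy, so among these three groups the hydroxy of compound 1 gives the lowest number and the order runs hydroxy, nitro, chloro. No measurement available here bears on why the three groups fall in this order.

As far as these compounds go, whether an amine or a methoxy group on this aromatic carbon would match or pass hydroxy stays open. Also open, from the compounds shown here alone, is whether the same order of hydroxy, nitro and chloro would hold on a different aromatic carbon of the ring.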